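Indole to Isobutylpyrazole: Cytotoxicity Expectation at the Limit

This account rests on a few compounds, and the source may have more. Where it says the series, first, only, none or still open, it means among the compounds named here.

Compound 1 `FC(F)(F)Oc1ccc(Nc2cc(-c3ccc4[nH]ccc4c3)ncn2)cc1` was tested in an ADME assay on BaF3 cells (Mus musculus) for cytotoxicity; on this read-out higher numbers stand for an effect only at larger amounts of compound and lower numbers for an effect already at smaller amounts. In this assay compound 1 gives > 10000 nM, which is a limit of the assay rather than a number. Compound 2 `NC(=O)CCn1ccc2c(Nc3ccc(OC(F)(F)F)cc3)ncnc21` gives > 10000 nM in this assay, again a limit. Compound 3 `O=C(O)c1cc2c(Nc3ccc(OC(F)(F)F)cc3)ncnc2s1` likewise gives > 10000 nM in this assay, also a limit. Among the compounds with values here, compound 1 thus stands at the limit of > 10000 nM in this assay, at which 3 of the 3 values shown sit, and because none of the three values is a number, no step between measured compounds can be drawn from them.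

Compound 4 `CC(C)Cn1cc(-c2cc(Nc3ccc(OC(F)(F)F)cc3)ncn2)cn1` has not yet been measured. It differs from compound 1 in one place: 1-isobutyl-1H-pyrazol-4-yl in place of 1H-indol-5-yl on an aromatic carbon. With every measured value sitting at the limit, there is no basis to expect this change to move compound 4 away from it. The step of a number no higher from compound 1 to compound 4 (the limit leaves the size open) is expected to stay within the scatter, most likely with the assay once more reporting only a limit. Compound 4 is therefore estimated to give 10000 nM in this assay, within a range from 5000 nM to 30000 nM.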

Compound 4, half-maximal effective concentration: > 10000 nM
Compound 4: only a limit was reported (the forecaster's own chance of this, stated with the estimate: 80%); the middle value sits exactly at the limit.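

Within the data shown here, compound 1 and compound 4 both sit at a limit rather than a number in this assay, so no step between them can be read. The compounds shown leave open at what amount any of them would show an effect, since all rest at one point: the limit of > 10000 nM in this assay, at which 4 of the 4 values shown sit.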